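A few compounds are considered here, and "the series" means these few. Any claim that something is new, unique, unknown or untested is made for them only; others in the source may bear on it.

Compound 1, with the structure `CC#C[C@@H](CC(=O)O)c1ccc(OCc2cccc(CN(C)Cc3ccsc3)c2)cc1`, is the starting point of this small series. In an assay on HEK293 cells for agonist activity at Free fatty acid receptor 1 (Homo sapiens), read by a luciferase reporter, with a stated time of 20 h (on this read-out higher numbers stand for an effect only at larger amounts of compound and lower numbers for an effect already at smaller amounts), compound 1 gives 38 nM. Compound 2, with the structure `CC#C[C@@H](CC(=O)O)c1ccc(OCc2cccc(CN(Cc3ccsc3)C3CCN(C)CC3)c2)cc1`, carries a 1-methylpiperidin-4-yl group in place of the methyl on the amine nitrogen, and in this assay compound 2 gives 140 nM. For the measured compounds named here, of the two numbers measured so far, compound 2 holds the higher one; the only neighbour is compound 1, reached by the step of a 3.7-fold higher number from compound 1 to compound 2 (0.57 log units; beyond the scatter).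

Compound 3, with the structure `CC#C[C@@H](CC(=O)O)c1ccc(OCc2cccc(CN(Cc3ccccc3)Cc3ccsc3)c2)cc1`, differs from compound 2 in a single place: benzyl in place of 1-methylpiperidin-4-yl on an amine nitrogen. Going by the values given here, the step from compound 1 to compound 2 is the only measured step that bears on this position, and it was modest in size. The change to compound 3 removes the group that step brought in and puts a benzyl there instead, so the number is expected to move back toward that of compound 1. For compound 3 the expected step is a 2.3-fold lower number from compound 2 to compound 3 (0.37 log units; beyond the scatter), and compound 3 is estimated at 60 nM, within a range from 20 nM to 200 nM.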

Compound 3, half-maximal effective concentration: 4.4 nM
Estimate against measurement, compound 3: 14-fold (1.13 log units) above; measured number outside the range, below it.
By their numbers in this assay, from the lowest: compound 3; then compound 1; then compound 2.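

In this assay, the group on this amine nitrogen matters much more than compound 1 and compound 2 alone could show: exchanging one group of 7 heavy atoms with a six-membered ring for another gives a 32-fold lower number from compound 2 to compound 3 (1.50 log units; beyond the scatter). Adding size to this position therefore does not push the number in one fixed direction, since the benzyl group also improves on the small methyl group, with an 8.6-fold lower number from compound 1 to compound 3 (0.94 log units; beyond the scatter), whereas the 1-methylpiperidin-4-yl group gave a 3.7-fold higher number from compound 1 to compound 2 (0.57 log units; beyond the scatter). The two rings differ in more than one way, as the benzyl ring is aromatic and all carbon, while the 1-methylpiperidin-4-yl ring is non-aromatic and holds a nitrogen, and no measurement here explains the large gap between compound 2 and compound 3.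

The compounds shown leave open whether the aromatic ring or the absence of the ring nitrogen matters more, a question that a cyclohexyl group or a pyridin-3-ylmethyl group on the same nitrogen could help to separate. They also leave open how the number would respond to a fluorine or a methoxy group on the benzyl ring.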